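The source may report more compounds than this note shows. Statements on the series, on what has been measured and on what is new or still open speak of the compounds shown alone.

Compound 1 `CCn1c(C(=O)NCCCN(C)C)ccc1C(CC)(CC)c1ccc(OCCC(O)(CC)CC)c(C)c1`: 2420 nM
Compound 2 `C#CCCOC(=O)c1ccc(C(CC)(CC)c2ccc(OCCC(O)(CC)CC)c(C)c2)n1CC`: > 50000 nM, a limit of the assay and not a number
Compound 3 `CCOC(=O)CN(C)C(=O)c1ccc(C(CC)(CC)c2ccc(OCCC(O)(CC)CC)c(C)c2)n1CC`: 1990 nM

In an ADME assay on L02 cells (Homo sapiens) for antiproliferative activity, read by MTT assay, with a stated time of 48 h (a higher number here means a weaker inhibitor, a lower number a stronger inhibitor), the data show a 1.2-fold lower number from compound 1 to compound 3 (0.08 log units; within the scatter), so compound 3 stands level with compound 1. The data also show an at least 25-fold lower number from compound 2 to compound 3 (1.40 log units; beyond the scatter).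

Compound 4 `CCOC(=O)C(CC(=O)OC)NC(=O)c1ccc(C(CC)(CC)c2ccc(OCCC(O)(CC)CC)c(C)c2)n1CC` keeps the shared core and changes only the group on a carbonyl carbon: a group of 12 heavy atoms (7 carbon, 1 nitrogen, 4 oxygen; no ring) in place of a group of 8 heavy atoms (5 carbon, 1 nitrogen, 2 oxygen; no ring), on a carbonyl carbon. Like compound 1 and compound 3, it is joined there through nitrogen, whereas compound 2 is joined through oxygen. The oxygen-linked group came with an at least 20-fold higher number from compound 1 to compound 2 (1.31 log units; beyond the scatter), while exchanging one nitrogen-linked group for another gave a 1.2-fold lower number from compound 1 to compound 3 (0.08 log units; within the scatter). The expected change is therefore small, with a 1.3-fold higher number from compound 3 to compound 4 (0.10 log units; within the scatter) estimated in this assay and no step beyond the scatter anticipated. The estimate for compound 4 is 2500 nM, with an expected range of 800 nM to 10000 nM.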

Compound 4, half-maximal inhibitory concentration: 4280 nM
Estimate against measurement, compound 4: 1.7-fold (0.23 log units) below; the measured number falls inside the stated range.
By their numbers in this assay, from the lowest: compounds 3, 1 and 4 (each within the scatter of the next, the first and the last beyond it). At a limit, above all of these: compound 2.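

Among the nitrogen-linked groups on this carbonyl carbon, the change can now exceed the scatter: a 2.2-fold higher number from compound 3 to compound 4 (0.33 log units; beyond the scatter), whereas a 1.8-fold higher number from compound 1 to compound 4 (0.25 log units; within the scatter) stays within it. The oxygen-linked compound 2 remains apart, with an at least 11-fold lower number from compound 2 to compound 4 (1.06 log units; beyond the scatter). The value of compound 2 is a limit of the assay and not a number: the limit of > 50000 nM in this assay, at which 1 of the 4 values shown sits.

From the compounds shown here alone, what a carboxylic acid in place of the esters of compound 4 would give in this assay remains open. So does the effect of a ring amine such as piperidine on this carbonyl carbon.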